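The source may report more compounds than this note shows. Statements on the series, on what has been measured and on what is new or still open speak of the compounds shown alone.

Compound 1 `C=C(c1ccc(OC)cc1NC(=O)CO)c1ccc(OC)c2c1OC(C)(C)C=C2`: 130 nM
Compound 2 `C=C(c1cc(OC)c(OC)c(OC)c1)c1ccc(OC)c(O)c1NC(C)=O`: 340 nM

Both values come from a functional assay on HCT-8 cells (Homo sapiens) for antiproliferative activity, read by MTT assay, with a stated time of 48 h; on this read-out lower numbers stand for stronger inhibition and higher numbers for weaker inhibition. Compound 2, at 340 nM, holds the higher of the two numbers and so shows the weaker inhibition, and its gap to compound 1 lies beyond the usual scatter. Compound 3 `C=C(c1cc(OC)c(OC)c(OC)c1)c1ccc(OC)c(O)c1NC(=O)COCC` is still unmeasured. It departs from compound 2 by ethoxy in place of hydrogen on a saturated chain carbon bound to a carbonyl carbon, turning acetamido into ((ethoxymethyl)carbonyl)amino. Among the compounds with values here, no measured pair isolates this change, so the expectation is tentative: a modest move towards weaker inhibition in this assay, starting from compound 2 at 340 nM. The expected change is a 1.5-fold higher number from compound 2 to compound 3 (0.17 log units; within the scatter). For compound 3 the estimated value is 500 nM, with an expected range of 150 nM to 1700 nM.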

Compound 3, half-maximal inhibitory concentration: 910 nM
Compound 3: middle estimate off by 1.8-fold (0.26 log units), on the low side; measured number inside the range.
By their numbers in this assay, from the lowest: compound 1; then compound 2; then compound 3.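

In this assay, within the data shown here, ethoxy in place of hydrogen on a saturated chain carbon bound to a carbonyl carbon gives a 2.7-fold higher number from compound 2 to compound 3 (0.43 log units; beyond the scatter), the first change that can be read at a single place. The position is therefore not indifferent to substitution: turning acetamido into ((ethoxymethyl)carbonyl)amino weakens inhibition on the shared core, although this one step gives a direction for ethoxy alone and no trend. Nothing at hand gives a reason for this loss.

From the compounds shown here alone, whether a dimethylamino group, a carboxylic acid or a plain propyl chain on the same carbon would also weaken inhibition remains open. Compound 1 differs from both other compounds in more than one place, so it cannot settle this question.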